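Replacing the aminocyclohexyl group of compound 3 with methoxybenzyl

This account rests on a few compounds, and the source may have more. Where it says the series, first, only, none or still open, it means among the compounds named here.

In a functional assay on G-361 cells (Homo sapiens) for cytotoxicity, read by fluorescence, with a stated time of 72 h (on this read-out lower numbers stand for stronger inhibition and higher numbers for weaker inhibition), compound 3 (`CC(C)c1n[nH]c2c(NCc3ccc(-c4ccccn4)cc3)nc(N[C@H]3CC[C@H](N)CC3)nc12`) gives 745 nM. This lies within the scatter of compound 1 (`CC(C)c1n[nH]c2c(NCc3ccc(-c4ccccn4)cc3)nc(S(C)(=O)=O)nc12`) at 793 nM, while compound 2 (`CC(C)c1n[nH]c2c(NCc3ccc(-c4ccccn4)cc3)nc(NCCO)nc12`) stands well lower at 39 nM. Compound 4 (`COc1ccc(CNc2nc(NCc3ccc(-c4ccccn4)cc3)c3[nH]nc(C(C)C)c3n2)cc1`) alters one group: 4-methoxybenzyl in place of 4-aminocyclohexyl on a nitrogen on an aromatic ring. In words, this is 4-methoxybenzyl in place of 4-aminocyclohexyl on a nitrogen on an aromatic ring. Measured swaps at this place gave a 20-fold lower number from compound 1 to compound 2 (1.31 log units; beyond the scatter) and a 19-fold higher number from compound 2 to compound 3 (1.28 log units; beyond the scatter), both large, but also a 1.1-fold lower number from compound 1 to compound 3 (0.03 log units; within the scatter), within the scatter. The place clearly can matter, yet none of these groups contains an aromatic ring, so the steps indicate no direction. The expected change is small, a 1.9-fold lower number from compound 3 to compound 4 (0.27 log units; within the scatter), with no step beyond the scatter anticipated. Compound 4 is estimated at 400 nM, within a range of 80 nM to 2000 nM.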

Compound 4, half-maximal inhibitory concentration: 7490 nM
Estimate against measurement, compound 4: 19-fold (1.27 log units) below; the measured number lies above the stated range.
By their numbers in this assay, from the lowest: compound 2; then compounds 3 and 1 (each within the scatter of the next); then compound 4.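

Among the groups at this place, 4-methoxybenzyl is the first with an aromatic ring, and it goes with weaker inhibition in this assay: there is a 10-fold higher number from compound 3 to compound 4 (1.00 log units; beyond the scatter) and a 9.4-fold higher number from compound 1 to compound 4 (0.98 log units; beyond the scatter) as well as a 190-fold higher number from compound 2 to compound 4 (2.28 log units; beyond the scatter) in the same assay. So the direction that the earlier steps left unsettled is now visible for this one aromatic group. No measured evidence explains the change.

The compounds shown leave open whether the ring or its methoxy group goes with this weaker inhibition. A plain benzyl group or a longer chain ending in a hydroxyl group could help separate these possibilities.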